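The source may report more compounds than this note shows. Statements on the series, on what has been measured and on what is new or still open speak of the compounds shown alone.

Compound 1 `CC(=O)Nc1cc(-c2ccc(OC[C@@H](N)CC(C)C)c(F)c2)ccn1` gives 1.6 nM in an assay on HEK293F cells for inhibition of AP2-associated protein kinase 1 (Homo sapiens), read by Western blot, with a stated time of 3 h; a higher number here means a weaker inhibitor, a lower number a stronger inhibitor. Among the compounds with values here, compound 2 `CC(=O)Nc1cc(-c2ccc(OC[C@@H](N)CC(C)C)c(Cl)c2)ccn1` gives 0.2 nM in this assay; the only measured step, an 8.0-fold lower number from compound 1 to compound 2 (0.90 log units; beyond the scatter), leaves compound 2 with the lower of the two numbers. Compound 3 `CC(=O)Nc1cc(-c2ccc(OC[C@@H](N)CC(C)C)c(OC(F)(F)F)c2)ccn1` differs from compound 2 by trifluoromethoxy in place of chloro on an aromatic carbon. Within the data shown here, no measured step covers this exchange; the one step, from fluoro to chloro, shows that this position tolerates change in either direction, so for compound 3 only a small upward step is expected, a 2.0-fold higher number from compound 2 to compound 3 (0.30 log units; within the scatter), within the scatter. Compound 3 is estimated at 0.4 nM in this assay, between 0.1 nM and 1.6 nM.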

Compound 3, half-maximal inhibitory concentration: 0.45 nM
The estimate for compound 3 lay 1.1-fold (0.05 log units) below the measured number; measured number inside the range.
By their numbers in this assay, from the lowest: compound 2; then compound 3; then compound 1.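

The exchange of chloro for trifluoromethoxy on this aromatic carbon, ortho to a (2-amino-4-methylpentyl)oxy group, gives a 2.3-fold higher number from compound 2 to compound 3 (0.35 log units; beyond the scatter) and so shows that a much larger group is accepted here at a modest loss. Set against fluoro, the same group gives a 3.6-fold lower number from compound 1 to compound 3 (0.55 log units; beyond the scatter) and so places the largest of the three groups in the middle of the order, with chloro lowest and fluoro highest. Nothing on hand gives a reason for this order.

On these data alone, a methyl, a methoxy or a nitrile on this carbon remains open. So does whether the order holds with a chain other than the (2-amino-4-methylpentyl)oxy group.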